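Replacing the Primary Amide of Compound 2 with Hydroxyethyl

The source may hold more compounds than are shown below. What is called first, only, known or untested is meant among the compounds shown, and "the series" means these compounds.

Of the compounds shown here, three sharing one core have been measured in a functional assay on HEK293 cells for agonist activity at Glucose-dependent insulinotropic receptor (Homo sapiens), read by reporter gene assay and cAMP accumulation, with a stated time of 6 h; on this read-out higher numbers stand for an effect only at larger amounts of compound and lower numbers for an effect already at smaller amounts. Compound 1 `CN(C)C(=O)C1CCN(c2nc(-c3cc(F)c(Cl)cc3F)nc3c2CS(=O)(=O)C3)CC1` gives 350 nM. Compound 2 `NC(=O)C1CCN(c2nc(-c3cc(F)c(Cl)cc3F)nc3c2CS(=O)(=O)C3)CC1` gives 21 nM, and compound 3 `NC(=O)CN1CCN(c2nc(-c3cc(F)c(Cl)cc3F)nc3c2CS(=O)(=O)C3)CC1` gives 44 nM. Compound 2 thus stands lowest of the three: its nearest neighbour is compound 3, and compound 1 lies furthest away. The step of a 17-fold lower number from compound 1 to compound 2 (1.22 log units; beyond the scatter) is large, whereas a 2.1-fold higher number from compound 2 to compound 3 (0.32 log units; beyond the scatter) is modest.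

Compound 4 `O=S1(=O)Cc2nc(-c3cc(F)c(Cl)cc3F)nc(N3CCC(CCO)CC3)c2C1` has not yet been measured in this assay. It differs from compound 2 as follows: 2-hydroxyethyl in place of carbamoyl on a saturated ring carbon. The step from compound 1 to compound 2 is the one that bears most directly on this change, since it shows how strongly the reading responds when the substituent on the carbonyl carbon is altered, and the step from compound 2 to compound 3 shows that a small rearrangement at the end of the saturated ring also moves the number beyond the scatter. Because a 17-fold lower number from compound 1 to compound 2 (1.22 log units; beyond the scatter) is so large, a change that removes the carbamoyl group altogether is expected to raise the number. The group that enters keeps one donor and one acceptor, so the step is estimated at a 3.8-fold higher number from compound 2 to compound 4 (0.58 log units; beyond the scatter) rather than anything like the full size of the first step. Compound 4 is therefore estimated at 80 nM, within 25 nM to 250 nM.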

Compound 4, effective concentration (reported as EC, without a stated level of effect): 2.8 nM
Beside the measured number, compound 4's estimate is 29-fold (1.46 log units) above it, outside the stated range (below it).
By their numbers in this assay, from the lowest: compound 4; then compound 2; then compound 3; then compound 1.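

In this assay, the saturated ring carbon three ring bonds from the ring nitrogen proves not to need a carbonyl for a low number: with 2-hydroxyethyl in place of carbamoyl there is a 7.5-fold lower number from compound 2 to compound 4 (0.88 log units; beyond the scatter), although both groups carry 3 heavy atoms, 1 hydrogen-bond donor and 1 hydrogen-bond acceptor, so these counts alone do not set the reading. Compound 4 now has the lowest number of the series, and its steps to the other two compounds are larger still, with a 16-fold lower number from compound 3 to compound 4 (1.20 log units; beyond the scatter) and a 130-fold lower number from compound 1 to compound 4 (2.10 log units; beyond the scatter), so the earlier gain from dimethylcarbamoyl to carbamoyl no longer marks the best substituent seen on this carbon. No supporting measurement is available to explain why 2-hydroxyethyl gives the lower number.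

The compounds shown leave open whether the hydroxyl group itself is needed, which a 2-methoxyethyl or plain ethyl group on the same ring carbon would address. They also leave open how the reading responds to chain length, as with a hydroxymethyl or 3-hydroxypropyl group, and to a carboxylic acid or an amine at the end of the chain.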